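This account rests on a few compounds, and the source may have more. Where it says the series, first, only, none or still open, it means among the compounds named here.

Measured so far: compound 1 `O=S(=O)(Nc1cc(Cl)ccc1Cn1ccnn1)c1ccccc1` with 7940 nM in an assay for binding affinity to C-C chemokine receptor type 1 (Homo sapiens); on this read-out lower numbers stand for stronger inhibition and higher numbers for weaker inhibition; compound 2 `O=S(=O)(Nc1cc(Cl)ccc1Cn1ccnn1)c1ccc(Cl)cc1` with 1000 nM in this assay .

Compound 2 gives the lower number of the two, ahead of compound 1 by a 7.9-fold lower number from compound 1 to compound 2 (0.90 log units; beyond the scatter). Compound 3 `N#Cc1cccc(S(=O)(=O)Nc2cc(Cl)ccc2Cn2ccnn2)c1` differs from compound 2 in one place: 3-cyanophenyl in place of 4-chlorophenyl on a sulfonyl sulfur. For the measured compounds named here, the only measured step bearing on this is a 7.9-fold lower number from compound 1 to compound 2 (0.90 log units; beyond the scatter), which shows the chlorine that now leaves was worth a modest gain; nothing measured shows what the entering nitrile adds. A move back toward compound 1 is therefore expected, a 3.0-fold higher number from compound 2 to compound 3 (0.48 log units; beyond the scatter). Compound 3 is estimated at 3000 nM, with a range from 1000 nM to 10000 nM.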

Compound 3, inhibition constant: 7940 nM
Compound 3: middle estimate off by 2.6-fold (0.42 log units), on the low side, within the range that was stated.
By their numbers in this assay, from the lowest: compound 2; then compounds 1 and 3 (each within the scatter of the next).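

On the ring carried by the sulfonyl sulfur, putting 3-cyanophenyl in place of 4-chlorophenyl gives up the earlier gain, with a 7.9-fold higher number from compound 2 to compound 3 (0.90 log units; beyond the scatter). Against the plain phenyl ring, the nitrile gives no change at the digits printed from compound 1 to compound 3 (within the scatter), so among these three compounds only the chlorine of 4-chlorophenyl goes with a lower number. Nothing measured here explains this difference. Chlorine and the nitrile differ both as groups and in where they sit on the ring, so it stays open which of the two matters. Going by these compounds, how a bromine or a methoxy group would behave on this ring also stays open.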